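Removing the tert-butyl group from compound 2

The source may hold more compounds than are shown below. What is called first, only, known or untested is meant among the compounds shown, and "the series" means these compounds.

Of the compounds shown here, three sharing one core have been tested in a functional assay on MDA-MB-231 cells (Homo sapiens) for cytotoxicity, read by MTT assay, with a stated time of 72 h; on this read-out lower numbers stand for stronger inhibition and higher numbers for weaker inhibition. Compound 1 `Cc1ccc(Cn2cc(/C=N/NC(=O)Nc3nc4ccc(CN5CCC(C)CC5)cc4s3)c3ccccc32)cc1` gives 1140 nM. Compound 2 `CC1CCN(Cc2ccc3nc(NC(=O)N/N=C/c4cn(Cc5ccc(C(C)(C)C)cc5)c5ccccc45)sc3c2)CC1` gives 3880 nM, and compound 3 `CN(C)Cc1ccc2nc(NC(=O)N/N=C/c3cn(Cc4ccc(C(C)(C)C)cc4)c4ccccc34)sc2c1` gives 2230 nM. On these numbers compound 2 stands highest: its gap to compound 3 is within the scatter, while a 3.4-fold higher number from compound 1 to compound 2 (0.53 log units; beyond the scatter) lies beyond it. The other measured step, a 1.7-fold lower number from compound 2 to compound 3 (0.24 log units; within the scatter), changes the group on the saturated chain carbon and falls within the scatter.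

Compound 4 `CC1CCN(Cc2ccc3nc(NC(=O)N/N=C/c4cn(Cc5ccccc5)c5ccccc45)sc3c2)CC1` differs from compound 2 in one place: hydrogen in place of tert-butyl on an aromatic carbon. The group that leaves has four heavy atoms, all carbon, no ring, and no hydrogen-bond donors or acceptors; only a hydrogen atom enters, on an aromatic carbon of a six-membered aromatic ring of carbon only, para to a large group.

For the measured compounds named here, the step that bears on this is the one from compound 1 to compound 2, where a tert-butyl replaced a methyl on the same aromatic carbon and the number rose beyond the scatter. Removing the tert-butyl altogether goes further in the opposite direction, so a lower number is expected for compound 4, roughly undoing that rise. Compound 4 is therefore estimated at 1300 nM in this assay, with a range from 500 nM to 3500 nM, which amounts to an expected step of a 3.0-fold lower number from compound 2 to compound 4 (0.47 log units; beyond the scatter).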

Compound 4, half-maximal inhibitory concentration: 2850 nM
Compound 4: the middle estimate sits 2.2-fold (0.34 log units) below what was measured; measured number inside the range.
By their numbers in this assay, from the lowest: compounds 1, 3, 4 and 2 (each within the scatter of the next, the first and the last beyond it).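

In this assay the change from 4-(tert-butyl)benzyl to benzyl brings only a 1.4-fold lower number from compound 2 to compound 4 (0.13 log units; within the scatter) and so hydrogen and tert-butyl cannot be told apart at this place on the ring. Methyl is a different matter, since hydrogen on the same aromatic carbon gives a 2.5-fold higher number from compound 1 to compound 4 (0.40 log units; beyond the scatter) and this modest step lies beyond the scatter. Taken with the earlier rise from methyl to tert-butyl, this means the numbers do not move steadily from hydrogen through methyl to tert-butyl: compound 1, with methyl, stands apart with a lower number than both compound 2 and compound 4, and that reading rests on this single compound.

Nothing shown here explains why methyl stands apart from the other two groups. Going by these compounds, whether an ethyl, a methoxy or a chlorine on the same aromatic carbon would read like methyl or like hydrogen remains open, as does whether methyl keeps its lower number when dimethylamino, as in compound 3, takes the place of 4-methylpiperidin-1-yl.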